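The source may report more compounds than this note shows. Statements on the series, on what has been measured and on what is new or still open speak of the compounds shown alone.

Only a thin set of numbers exists for this series in an ADME assay on a cell-free system (plasma, Rattus norvegicus); on this read-out lower numbers stand for a smaller free fraction and higher numbers for a larger free fraction. Among the compounds with values here, in that test, compound 1 (`CCCS(=O)(=O)c1ccc(F)c(C#Cc2cc(Cl)ccc2OCC(=O)O)c1`) gives 0.004, the only actual number available. Compound 2 (`Cc1ccc(S(=O)(=O)N(C)C(C)C)cc1C#Cc1cc(Cl)ccc1OCC(=O)O`) is recorded as "not determined" (no result reported). Compound 3 (`Cc1ccc(S(=O)(=O)N2CCCCC2C)cc1C#Cc1cc(Cl)ccc1OCC(=O)O`) is also recorded as "not determined" (no result reported), so it has no place on the scale and offers no starting value.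

The next structure is compound 4 (`Cc1ccc(S(C)(=O)=O)cc1C#Cc1cc(Cl)ccc1OCC(=O)O`), which has methyl in place of 2-methylpiperidin-1-yl on a sulfonyl sulfur. Within the data shown here, no measured pair shows what a change of this kind does, so any forecast is a cautious one. Among the measured compounds shown here, the only anchor is compound 1 at 0.004, which also carries a sulfonyl group but differs from compound 4 elsewhere too. From that anchor, a modest step towards a larger free fraction is expected in this assay, perhaps only slightly beyond the usual scatter, though no change at all would not be surprising. For compound 4 the estimated value is 0.01, with an expected range from 0.004 to 0.025.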

Compound 4, unbound fraction: 0.014
Beside the measured number, compound 4's estimate is 1.4-fold (0.15 log units) below it; low and high end bracket the measured number.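

In this assay compound 4 gives 0.014, yet no new step can be read: compound 3 has no single number to set against it. The effect on free fraction of replacing 2-methylpiperidin-1-yl with methyl on the sulfonyl sulfur stays open, and no evidence at hand explains the value of compound 4.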